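A Third Methoxy on a Shared Core

The compounds below may be only part of what the source reports. "The series", "measured", "known", "first", "only" and "open" are said of these compounds alone.

Compound 2 `COc1ccc(CNc2nc3cc(N)cc(N)c3nc2-c2ccccc2)cc1OC` sits at a limit of the assay: in a functional assay on EKVX cells (Homo sapiens) for inhibition, read by sulforhodamine B assay, with a stated time of 48 h (on this read-out higher numbers stand for lower toxicity in this test and lower numbers for higher toxicity in this test), compound 2 gives < 100000 nM, which is a limit and not a number. Compound 1 `Nc1cc(N)c2nc(-c3ccccc3)c(NCc3ccc(Cl)c(Cl)c3)nc2c1` likewise gives only a limit, as in this assay compound 1 gives < 100000 nM. Among the compounds with values here, the one measured step, a step that the two limits leave unreadable from compound 1 to compound 2, is therefore unreadable, and the limit of < 100000 nM in this assay, at which 2 of the 2 values shown sit, shows both values at the same limit. Compound 3 `COc1cc(CNc2nc3cc(N)cc(N)c3nc2-c2ccccc2)cc(OC)c1OC` differs from compound 2 by methoxy in place of hydrogen on an aromatic carbon. Within the data shown here, no measured step speaks to this change, so nothing beyond the scatter is expected in this assay. The expected step is a step that the limit leaves unreadable from compound 2 to compound 3. Compound 3 is expected to give about 50000 nM, between 10000 nM and 200000 nM.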

Compound 3, concentration lethal to 50% of the cells: 27500 nM
Beside the measured number, compound 3's estimate is 1.8-fold (0.26 log units) above it, within the range that was stated.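

Compound 2 gives only a limit, so no step can be read from compound 2 to compound 3: the limit of < 100000 nM in this assay, at which 2 of the 3 values shown sit. On these data alone, whether the added methoxy changes the result in this assay at all, and by how much, stays open.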